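Notes: shifting the methyl, compound 3 to compound 4

The source may report more compounds than this note shows. Statements on the series, on what has been measured and on what is new or still open speak of the compounds shown alone.

Values in a functional assay on HT-29 cells (Homo sapiens) for cytotoxicity, read by MTT assay; a higher number here means a weaker inhibitor, a lower number a stronger inhibitor:
- compound 1 `COc1ccc(OC)c(C(=O)/C=C/c2ccoc2)c1`: 21300 nM
- compound 2 `COc1ccc(OC)c(C(=O)/C=C/c2cccs2)c1`: 13300 nM
- compound 3 `COc1ccc(OC)c(C(=O)/C=C/c2ccc(C)s2)c1`: 1800 nM

Compound 3 has the lowest number of the three in this assay, and its steps to both others lie beyond the scatter. Compound 4 `COc1ccc(OC)c(C(=O)/C=C/c2sccc2C)c1` carries 3-methylthiophen-2-yl in place of 5-methylthiophen-2-yl on a double-bonded chain carbon bound to a double-bonded chain carbon. Within the data shown here, no measured step moves a methyl group, so the size of this change cannot be read directly from the data. The closest evidence is a 7.4-fold lower number from compound 2 to compound 3 (0.87 log units; beyond the scatter), where methyl replaces hydrogen on an aromatic carbon. The larger 12-fold lower number from compound 1 to compound 3 (1.07 log units; beyond the scatter) combines that methyl with the change of heteroaryl group, whereas a 1.6-fold lower number from compound 1 to compound 2 (0.20 log units; within the scatter) shows little from that change alone. Compound 4 keeps the methyl, but the data do not show how much of a 7.4-fold lower number from compound 2 to compound 3 (0.87 log units; beyond the scatter) remains once it has moved. A result between those of compound 3 and compound 2 is therefore expected, closer to compound 3. The expected change is modest, towards a higher number: a 2.2-fold higher number from compound 3 to compound 4 (0.35 log units; beyond the scatter). For compound 4 the estimate is 4000 nM, with an expected range of 1300 nM to 13000 nM.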

Compound 4, half-maximal inhibitory concentration: 19400 nM
Compound 4: middle estimate off by 4.9-fold (0.69 log units), on the low side; the measured number lies above the stated range.
By their numbers in this assay, from the lowest: compound 3; then compounds 2, 4 and 1 (each within the scatter of the next).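

Position decides the outcome in this assay: with the same atoms joined differently, 3-methylthiophen-2-yl in place of 5-methylthiophen-2-yl gives a large step (an 11-fold higher number from compound 3 to compound 4 (1.03 log units; beyond the scatter)), so the presence of a methyl alone does not account for the low number of compound 3. Methyl in place of hydrogen on an aromatic carbon has no fixed worth in this short series, since the step that yields 3-methylthiophen-2-yl stays within the scatter (a 1.5-fold higher number from compound 2 to compound 4 (0.16 log units; within the scatter)), unlike the step that yields 5-methylthiophen-2-yl, and compound 4 also remains within the scatter of the furan-3-yl compound (a 1.1-fold lower number from compound 1 to compound 4 (0.04 log units; within the scatter)). The data at hand offer no measurement that explains why the two methyl placements part so widely.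

The compounds shown leave open whether the gain seen with 5-methylthiophen-2-yl belongs to methyl itself or would also appear with ethyl, chlorine, methoxy or a carboxylic acid in that same place. They also leave open whether the same methyl placements would give the same large step on a furan-3-yl group.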